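A few compounds are considered here, and "the series" means these few. Any claim that something is new, unique, unknown or untested is made for them only; others in the source may bear on it.

Of the compounds shown here, three have been measured in a physicochemical assay for lipophilicity, read by HPLC, measured as chromatographic lipophilicity, at pH 7.4; on this read-out lower numbers stand for lower lipophilicity and higher numbers for higher lipophilicity. Compound 1 `N#Cc1ccc(N2CCC(C(=O)N3N=CC[C@H]3c3cc(F)cc(F)c3)CC2)nn1` gives 4.8, compound 2 `O=C(C1CCN(c2ccncn2)CC1)N1N=CC[C@H]1c1ccccc1` gives 3.2, and compound 3 `CC(C)(C)C(=O)N1N=CCC1c1cc(F)cc(F)c1` gives 6.3. Compound 2 therefore stands lowest of the three numbers: compound 1 lies higher by an amount beyond the scatter, and compound 3 lies higher still, also beyond the scatter. Among the compounds with values here, no two of the measured compounds differ in only one place, so there is no measured single step to lean on.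

Compound 4 `O=C(C1CCN(c2ccccn2)CC1)N1N=CC[C@H]1c1ccccc1` has not yet been measured. It differs from compound 2 in one place: pyridin-2-yl in place of pyrimidin-4-yl on an amine nitrogen in a ring. The change swaps a six-membered aromatic ring with 2 hetero atoms for a six-membered aromatic ring with 1 hetero atom, at the same amine nitrogen in a ring. On this assay a swap of this kind is expected to move the number upward by a moderate amount, beyond the scatter. The step of a number 0.80 log units higher from compound 2 to compound 4 (beyond the scatter) is the expected size of that move. Compound 4 is accordingly estimated at 4, with a range from 3.5 to 4.6.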

Compound 4, distribution coefficient: 5.1
Estimate against measurement, compound 4: 1.10 log units below; the whole stated range lies below it.
By their numbers in this assay, from the lowest: compound 2; then compounds 1 and 4 (each within the scatter of the next); then compound 3.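

In this assay, this place, on an amine nitrogen in a ring, now has its first measured single step: pyridin-2-yl in place of pyrimidin-4-yl gives a number 1.90 log units higher from compound 2 to compound 4 (beyond the scatter), a large move. The two groups have the same count of heavy atoms, and the swap exchanges one ring nitrogen for a carbon and leaves one hydrogen-bond acceptor fewer. So at this place, a large step on this read-out can come from a change that leaves the number of heavy atoms in the group untouched.

Still open, on these data alone, is where a pyrazin-2-yl ring or a plain phenyl ring would fall at this place, and whether the swap gives a step of similar size on the core of compound 1. Nothing measured here accounts for the size of this step.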